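The compounds below may be only part of what the source reports. "The series", "measured", "known", "first", "only" and "open" are said of these compounds alone.

For the measured compounds named here, in an ADME assay on cells (Homo sapiens) for cytotoxicity, read by polymerase chain reaction, with a stated time of 3 days (on this read-out lower numbers stand for higher toxicity in this test and higher numbers for lower toxicity in this test), compound 3 `CCNc1nc(C)c(-c2nc3ccccc3s2)c(N[C@@H]2C[C@H](CO)[C@@H](O)[C@H]2O)n1` is the only compound of the three with a value that is a number: compound 3 gives 12000 nM. Compound 1 `Nc1nc(Cl)c(-c2ccco2)c(N[C@@H]2C[C@H](CO)[C@@H](O)[C@H]2O)n1` gives > 25000 nM, which is a limit of this assay and not a number. Compound 2 `Nc1nc(Cl)c(-c2ncco2)c(N[C@@H]2C[C@H](CO)[C@@H](O)[C@H]2O)n1` likewise gives > 25000 nM, again a limit. The step from one to the other, a step that the two limits leave unreadable from compound 1 to compound 2, cannot be read, because the limit of > 25000 nM in this assay, at which 2 of the 3 values shown sit, holds both ends.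

Compound 4 `Cc1nc(NCc2nccs2)nc(N[C@@H]2C[C@H](CO)[C@@H](O)[C@H]2O)c1-c1nc2ccccc2s1` differs from compound 3 in one place: 1,3-thiazol-2-yl in place of methyl on a saturated chain carbon bound to a nitrogen on an aromatic ring. Going by the values given here, none of the measured steps touches the ethylamino group, and the one measured step is unreadable, so no measured step bears directly on this change. The expectation can therefore rest only on compound 3 itself. The step from compound 3 to compound 4 is expected to be no change at the digits printed from compound 3 to compound 4 (within the scatter), with the limit of this assay lying within reach. Compound 4 is estimated at 12000 nM, in the range 4000 nM to 30000 nM.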

Compound 4, half-maximal cytotoxic concentration: 23000 nM
Estimate against measurement, compound 4: 1.9-fold (0.28 log units) below; low and high end bracket the measured number.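

In this assay the change gives a 1.9-fold higher number from compound 3 to compound 4 (0.28 log units; within the scatter). For the compounds shown here, this is the first readable step in the set, and it shows that on this saturated chain carbon, the small ethyl of the ethylamino group can give way to (1,3-thiazol-2-yl)methyl, with its five-membered aromatic ring, without moving the reading beyond the usual scatter of repeated measurements. Both readings on this position lie in the upper part of the range shown, and the end of that range is a limit: the limit of > 25000 nM in this assay, at which 2 of the 4 values shown sit.

Still open, as far as these compounds go, is whether a primary amine, a carboxylic acid or a longer alkyl chain in place of the ethyl would leave the reading just as undisturbed. Also open, from the compounds shown here alone, is whether (1,3-thiazol-2-yl)methyl would read the same on the core of compound 1, whose step to compound 2 cannot be read.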